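The compounds below may be only part of what the source reports. "The series", "measured", "known", "first", "only" and "open" are said of these compounds alone.

Among the compounds with values here, compound 2 `Cc1[nH]n(-c2ccc(I)cc2)c(=O)c1/N=N/c1c(O)cc(S(=O)(=O)O)c2ccccc12` is the one compound with a numeric read-out in an assay on BaF3 cells with thrombopoietin receptor (Homo sapiens) as the target, read by a luciferase reporter (on this read-out lower numbers stand for smaller maximal responses and higher numbers for larger maximal responses), where compound 2 reaches 81%. Compound 1 `Oc1ccc2ccccc2c1/N=N/c1c(O)ccc2ccccc12` gives only a limit in this assay, < 5%; this is the limit of < 5% in this assay, at which 1 of the 2 values shown sits. Compound 3 `Cc1[nH]n(-c2ccc(S(=O)(=O)O)cc2)c(=O)c1/N=N/c1c(O)cc(S(=O)(=O)O)c2ccccc12` differs from compound 2 by sulfo in place of iodo on an aromatic carbon. Within the data shown here, no measured pair shows the effect of such a change, so the size of the step is uncertain; a loss beyond the usual scatter seems more likely than a gain, given that compound 2 already sits at 81%. For compound 3 the expected maximal response is 60%, from 15% to 95%. This means an expected step of a number 21 percentage points lower from compound 2 to compound 3 (beyond the scatter).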

Compound 3, largest response reached (reported as efficacy), in percent of the reference or control that the assay uses: < 5%
Compound 3 was reported as a limit (the forecaster's own chance of this, stated with the estimate: 20%); middle value at least 55 percentage points from the limit.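

In this assay, replacing 4-iodophenyl with 4-sulfophenyl gives a number at least 76 percentage points lower from compound 2 to compound 3 (beyond the scatter). Within the data shown here, this is the first measured step at this position, and it shows that the maximal response depends strongly on the group held there. Compound 3 gives a limit rather than a number, so the step is only a minimum: the limit of < 5% in this assay, at which 2 of the 3 values shown sit.

The compounds shown do not tell whether the loss comes from adding sulfo or from removing iodo. From the compounds shown here alone, how a carboxylic acid, an amine or a methyl group would behave at this position also remains open.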